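The source may hold more compounds than are shown below. What is called first, only, known or untested is meant among the compounds shown, and "the series" means these compounds.

Three compounds have been measured in a functional assay on K562 cells (Homo sapiens), read by MTT assay, with a stated time of 72 h; a higher number here means a weaker inhibitor, a lower number a stronger inhibitor:

Compound 1 `C#Cc1cn([C@@H]2O[C@H](CO)[C@@H](O)[C@H]2O)c2ncnc(OC)c12` gives 300 nM.
Compound 2 `COc1ncnc2c1c(-c1ccco1)cn2[C@@H]1O[C@H](CO)[C@@H](O)[C@H]1O` gives 60 nM.
Compound 3 `C#Cc1cn([C@@H]2O[C@H](CO)[C@@H](O)[C@H]2O)c2ncnc(N(C)C)c12` gives 110 nM.

Compound 1 shows the highest number of the three, so it is the weakest inhibitor here; both changes made to it lowered the number, a 5.0-fold lower number from compound 1 to compound 2 (0.70 log units; beyond the scatter) and a 2.7-fold lower number from compound 1 to compound 3 (0.44 log units; beyond the scatter), each a modest step beyond the scatter. Compound 4 `C#Cc1cn([C@@H]2O[C@H](CO)[C@@H](O)[C@H]2O)c2nc(N)nc(OC)c12` is the next variation on compound 1. The change is amino in place of hydrogen on an aromatic carbon. This differs in kind from the two measured steps: those replaced the ethynyl group or the methoxy group, while here a hydrogen on the shared core is replaced and both of those groups stay in place. Neither measured step therefore bears directly on this change, and nothing in the data tells how an amino group in this position affects the result. The expectation for compound 4 is accordingly a step of no change at the digits printed from compound 1 to compound 4 (within the scatter), that is none beyond the scatter, with a wide range to reflect the lack of any direct comparison. Compound 4 is thus estimated at 300 nM, between 100 nM and 900 nM.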

Compound 4, half-maximal inhibitory concentration: > 20000 nM
Compound 4: only a limit was reported (the forecaster's own chance of this, stated with the estimate: 5%); at least 66-fold (1.82 log units) between middle value and limit.
By their numbers in this assay, from the lowest: compounds 2 and 3 (each within the scatter of the next); then compound 1. At a limit, above all of these: compound 4.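

This position on the shared core, on an aromatic carbon between two ring nitrogen atoms, proves highly sensitive: amino in place of hydrogen gives an at least 66-fold higher number from compound 1 to compound 4 (1.82 log units; beyond the scatter), whereas both earlier changes, made elsewhere on compound 1, lowered the number. For compound 4, > 20000 nM in this assay is a limit and not a number. The result therefore rests on a limit: the limit of > 20000 nM in this assay, at which 1 of the 4 values shown sits.

Still open, from the compounds shown here alone, is whether this large step is specific to the amino group or would also follow from another replacement for this hydrogen, such as a methyl group or a chlorine atom. Also open, going by these compounds, is whether an amino group here would have the same effect alongside dimethylamino in place of methoxy, or alongside furan-2-yl in place of ethynyl.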